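The compounds below may be only part of what the source reports. "The series", "measured", "known", "first", "only" and "open" are said of these compounds alone.

Compound 1, `COc1ccc(Oc2ccccc2-c2ccsc2S(=O)(=O)NCCNC(=S)Nc2cc(C(F)(F)F)cc(C(F)(F)F)c2)cc1OC`, and compound 2, `COc1ccc(Oc2ccc(C(C)C)cc2-c2ccsc2S(=O)(=O)NCCNC(=S)Nc2cc(C(F)(F)F)cc(C(F)(F)F)c2)cc1OC`, share one core and differ in a single place: isopropyl in place of hydrogen on an aromatic carbon. In a functional assay on HeLa cells (Homo sapiens) for inhibition, read by CCK-8 assay, with a stated time of 48 h (a higher number here means a weaker inhibitor, a lower number a stronger inhibitor), compound 1 gives 6400 nM. In this assay compound 2 gives 8300 nM. The step of a 1.3-fold higher number from compound 1 to compound 2 (0.11 log units; within the scatter) lies within the scatter, so these two values cannot be told apart.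

Compound 3, `O=C(NCCNS(=O)(=O)c1sccc1-c1ccccc1Oc1ccc(O)c(O)c1)Nc1cc(C(F)(F)F)cc(C(F)(F)F)c1`, is built on a different core, and how its core differs from that of compound 1 is not broken down here. In this assay compound 3 gives only a limit, > 50000 nM, and no number. That limit is the limit of > 50000 nM in this assay, at which 1 of the 3 values shown sits.

Compound 4, `CC(C)c1ccc(Oc2ccc(O)c(O)c2)c(-c2ccsc2S(=O)(=O)NCCNC(=O)Nc2cc(C(F)(F)F)cc(C(F)(F)F)c2)c1`, has not yet been measured. It differs from compound 3 in one place: isopropyl in place of hydrogen on an aromatic carbon. Among the measured compounds shown here, this is the same kind of change as the one between compound 1 and compound 2, though the surroundings are not identical: in compound 2 the isopropyl sits para to a 3,4-dimethoxyphenoxy group, while in compound 4 it sits para to a 3,4-dihydroxyphenoxy group. The step here is expected to be small as well, a step that the limit leaves unreadable from compound 3 to compound 4, because the same kind of change gave a 1.3-fold higher number from compound 1 to compound 2 (0.11 log units; within the scatter). Compound 4 is therefore expected to give about 70000 nM in this assay, somewhere between 30000 nM and 200000 nM, and most likely once more only a limit rather than a number.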

Compound 4, half-maximal inhibitory concentration: > 50000 nM
Compound 4: no number, only a limit; the forecaster's own chance of this, stated with the estimate: 75%; the middle value lies beyond the limit too.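

In this assay compound 4 gives > 50000 nM as a limit and not a number. Among the compounds shown here, compound 3 also gives only a limit, so no step from compound 3 to compound 4 can be read: the limit of > 50000 nM in this assay, at which 2 of the 4 values shown sit.

The compounds shown leave open whether isopropyl in place of hydrogen on an aromatic carbon changes the read-out at all when the ring carries a 3,4-dihydroxyphenoxy group.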